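The source may hold more compounds than are shown below. What is called first, only, known or untested is meant among the compounds shown, and "the series" means these compounds.

Measured so far:
Compound 1 `CC(c1ccc(-c2ccccc2)c(F)c1)c1nnc2n1N=C(c1ccc(Cl)cc1)CS2` in a functional assay on HepG2 cells (Homo sapiens) for inhibition, read by sulforhodamine B assay, with a stated time of 72 h (a higher number here means a weaker inhibitor, a lower number a stronger inhibitor), gives 6700 nM.
Compound 2 `CC(c1ccc(-c2ccccc2)c(F)c1)c1nnc2n1N=C(c1ccc(F)cc1)CS2` in this assay gives 5100 nM.

Compound 2 holds the smaller of the two numbers shown, yet the step of a 1.3-fold lower number from compound 1 to compound 2 (0.12 log units; within the scatter) stays within the scatter, so the two compounds are not told apart. Compound 3 `CC(c1ccc(-c2ccccc2)c(F)c1)c1nnc2n1N=C(c1ccc([N+](=O)[O-])cc1)CS2` differs from compound 2 by nitro in place of fluoro on an aromatic carbon. Going by the values given here, no measured step exchanges fluoro for nitro; the only step seen, a 1.3-fold lower number from compound 1 to compound 2 (0.12 log units; within the scatter), swaps one halogen for another and bears only loosely on this change. Compound 3 is therefore expected to show a step of a 1.0-fold lower number from compound 2 to compound 3 (0.01 log units; within the scatter) that stays within the scatter. The estimate for compound 3 in this assay is 5000 nM, ranging from 1500 nM to 16000 nM.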

Compound 3, half-maximal inhibitory concentration: 4300 nM
Estimate against measurement, compound 3: 1.2-fold (0.07 log units) above; low and high end bracket the measured number.
By their numbers in this assay, from the lowest: compounds 3, 2 and 1 (each within the scatter of the next).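

Replacing a single halogen atom with nitro, a larger group that brings hydrogen-bond acceptors, still does not separate the compounds in this assay: a 1.2-fold lower number from compound 2 to compound 3 (0.07 log units; within the scatter) and a 1.6-fold lower number from compound 1 to compound 3 (0.19 log units; within the scatter) are both small steps. Chloro, fluoro and nitro at this position on the aromatic ring therefore give numbers that cannot be told apart. Nothing available explains this result.

Still open, on these data alone, is whether an amine or a carboxylic acid on this same aromatic carbon would move the number beyond the scatter.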